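Aryl variation on an acetylated glycoside scaffold

The source may report more compounds than this note shows. Statements on the series, on what has been measured and on what is new or still open speak of the compounds shown alone.

Measured compounds:
- compound 1 `CC(=O)OC[C@H]1O[C@@H](n2cc(CN3C(=O)/C(=C\c4ccccc4)c4ccccc43)nn2)[C@H](OC(C)=O)[C@@H](OC(C)=O)[C@@H]1OC(C)=O`: 24300 nM
- compound 2 `COc1ccc(/C=C2\C(=O)N(Cc3cn([C@@H]4O[C@H](COC(C)=O)[C@@H](OC(C)=O)[C@H](OC(C)=O)[C@H]4OC(C)=O)nn3)c3ccccc32)cc1OC`: 23500 nM
- compound 3 `CC(=O)OC[C@H]1O[C@@H](n2cc(CN3C(=O)/C(=C\C=C\c4ccccc4)c4ccccc43)nn2)[C@H](OC(C)=O)[C@@H](OC(C)=O)[C@@H]1OC(C)=O`: 34100 nM

In a functional assay on MCF7 cells (Homo sapiens) for cytotoxicity, read by sulforhodamine B assay, with a stated time of 48 h (on this read-out lower numbers stand for stronger inhibition and higher numbers for weaker inhibition), compound 3 gives the highest of the three numbers, yet the two steps that lead to it, a 1.4-fold higher number from compound 1 to compound 3 (0.15 log units; within the scatter) and a 1.5-fold higher number from compound 2 to compound 3 (0.16 log units; within the scatter), both lie within the scatter, so no order among the three can be claimed. Compound 4 `CC(=O)OC[C@H]1O[C@@H](n2cc(CN3C(=O)/C(=C\c4ccc(N(C)C)cc4)c4ccccc43)nn2)[C@H](OC(C)=O)[C@@H](OC(C)=O)[C@@H]1OC(C)=O` differs from compound 3 by 4-(dimethylamino)phenyl in place of 2-phenylethenyl on a double-bonded chain carbon bound to a double-bonded ring carbon. The steps from compound 1 and compound 2, each carrying an aryl group at that position, to the phenylethenyl compound 3 bear directly on this change, and neither went beyond the scatter. The step from compound 3 to compound 4 is therefore expected to be small, a 1.4-fold lower number from compound 3 to compound 4 (0.13 log units; within the scatter), if anything toward a lower number in this assay. Compound 4 is estimated at 25000 nM, within 12000 nM to 50000 nM.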

Compound 4, half-maximal inhibitory concentration: 29800 nM
The estimate for compound 4 lay 1.2-fold (0.08 log units) below the measured number; the measured number falls inside the stated range.
By their numbers in this assay, from the lowest: compounds 2, 1, 4 and 3 (each within the scatter of the next).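

In this assay, dimethylamino in place of hydrogen on an aromatic carbon gives a 1.2-fold higher number from compound 1 to compound 4 (0.09 log units; within the scatter), so this nitrogen-bearing group changes nothing that can be read at this position. Against the other two groups, 4-(dimethylamino)phenyl gives a 1.1-fold lower number from compound 3 to compound 4 (0.06 log units; within the scatter) and a 1.3-fold higher number from compound 2 to compound 4 (0.10 log units; within the scatter), so all four groups on a double-bonded chain carbon bound to a double-bonded ring carbon remain within the scatter of one another. No measurement shown here accounts for this. Going by these compounds, whether a carboxylic acid or a primary amine in place of dimethylamino would give a step beyond the scatter remains open.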